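A few compounds are considered here, and "the series" means these few. Any claim that something is new, unique, unknown or untested is made for them only; others in the source may bear on it.

Within the data shown here, in an ADME assay on MDBK cells (Bos taurus) for cytotoxicity (a higher number here means that more compound is tolerated, a lower number that less compound is tolerated), compound 2 `Ic1ccc(Cn2ccc3nc(-c4ccccc4)nc-3c2)cc1` gives 22000 nM, the only actual number recorded. Compound 1 `c1ccc(Cn2ccc3nc(-c4ccccc4)nc-3c2)cc1` reaches only a limit of this assay, > 100000 nM. Among the measured compounds shown here, the single measured step, an at least 4.5-fold lower number from compound 1 to compound 2 (0.65 log units; beyond the scatter), has a size that depends on (the limit of > 100000 nM in this assay, at which 1 of the 2 values shown sits). Compound 3 `Clc1ccc(Cn2ccc3nc(-c4ccccc4)nc-3c2)s1` differs from compound 2 by 5-chlorothiophen-2-yl in place of 4-iodophenyl on a saturated chain carbon bound to an aromatic nitrogen. For the measured compounds named here, that change exchanges a whole ring, which the one measured step does not cover, so only a weak guide exists for it. The expected change is therefore a 1.1-fold higher number from compound 2 to compound 3 (0.06 log units; within the scatter), not beyond the scatter. Compound 3 is estimated at 25000 nM, with a range from 8000 nM to 80000 nM.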

Compound 3, half-maximal cytotoxic concentration: > 100000 nM
Compound 3 gave a limit, no number; the forecaster's own chance of this, stated with the estimate: 10%; middle value at least 4.0-fold (0.60 log units) away from the limit.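

At this position, a whole-ring exchange can shift the result clearly: in this assay, 5-chlorothiophen-2-yl in place of 4-iodophenyl gives an at least 4.5-fold higher number from compound 2 to compound 3 (0.65 log units; beyond the scatter). A halogen on this ring therefore does not always go with a lower number, since compound 3 carries chlorine and compound 2 iodine. The step from compound 1 to compound 3 cannot be read, with both compounds reaching a limit: the limit of > 100000 nM in this assay, at which 2 of the 3 values shown sit.

Going by these compounds, it stays open whether the halogen or the ring type drives this difference. A 4-chlorophenyl or unsubstituted thiophen-2-yl group would separate the two.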